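Swapping the group on the ring nitrogen

A few compounds are considered here, and "the series" means these few. Any claim that something is new, unique, unknown or untested is made for them only; others in the source may bear on it.

Compound 1 `Nc1scc(CN2CCN(c3cccc(C(F)(F)F)c3)CC2)c1C(=O)c1ccc(Cl)cc1` was tested in an assay on CHO cells for displacement of a labelled ligand from adenosine receptor A3 (Homo sapiens), read by scintillation counting, with a stated time of 120 min, tested at 10 uM (a lower number here means less inhibition, a higher number more inhibition at the concentration tested (going by the name of the read-out)), where compound 1 gives 0%. Two close relatives differ from it only in the group attached to an amine nitrogen in a ring. In this assay compound 2 `Nc1scc(CN2CCN(c3ccc(OC(F)(F)F)cc3)CC2)c1C(=O)c1ccc(Cl)cc1` gives 1%, and compound 3 `Nc1scc(CN2CCN(c3cccnc3)CC2)c1C(=O)c1ccc(Cl)cc1` gives 0%. The steps between them are small: a number 1 percentage points higher from compound 1 to compound 2 (within the scatter), no change at the digits printed from compound 1 to compound 3 (within the scatter), and a number 1 percentage points lower from compound 2 to compound 3 (within the scatter). Compound 1 therefore sits level with compound 3, and all three show essentially no inhibition at the concentration used.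

Compound 4 `Nc1scc(CN2CCN(c3c(F)cccc3F)CC2)c1C(=O)c1ccc(Cl)cc1` changes the same position once more: 2,6-difluorophenyl in place of 3-(trifluoromethyl)phenyl on an amine nitrogen in a ring. All three measured steps bear on this change, since each replaces the group at this position, and none of them moved the number beyond the usual scatter. The step expected here is a number 1 percentage points higher from compound 1 to compound 4 (within the scatter), which is to say no change beyond the scatter. Compound 4 is estimated at 1%, with a likely range from 0% to 10%.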

Compound 4, a percentage reported as inhibition, at one concentration (the size of the read-out at that concentration, not a potency): 4%
Estimate against measurement, compound 4: 3 percentage points below; the range from low to high includes it.
By their numbers in this assay, from the lowest: compounds 1, 3, 2 and 4 (each within the scatter of the next).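

The 2,6-difluorophenyl group is a fourth ring at this position, and in this assay it too leaves the number within the scatter, with a number 4 percentage points higher from compound 1 to compound 4 (within the scatter) and a number 4 percentage points higher from compound 3 to compound 4 (within the scatter) and also a number 3 percentage points higher from compound 2 to compound 4 (within the scatter) all small. Moving from a single fluorine-bearing substituent to two fluorine atoms on the ring, with fewer heavy atoms overall, therefore gives no readable change, so the flat picture now covers four different ring groups. No measurement here bears on why these numbers stay so low.

With all four compounds this close together at one concentration, they cannot be ranked and the position's importance stays unsettled. On these data alone, whether a non-aromatic group on this nitrogen, such as a carboxylic acid chain or a simple amine-bearing chain, would give clear inhibition remains open.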